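The source may hold more compounds than are shown below. What is called first, only, known or untested is meant among the compounds shown, and "the series" means these compounds.

Measured in a functional assay on A2780 cells (Homo sapiens) for antiproliferative activity, read by fluorescence, with a stated time of 72 h; a lower number here means a stronger inhibitor, a higher number a weaker inhibitor:
- compound 1 `CN1CCC(C(=O)N2Cc3c(NC(=O)C4CCC4)n[nH]c3C2(C)C)CC1`: 140 nM
- compound 2 `CN1CCC(C(=O)N2Cc3c(NC(=O)NCc4ccccc4)n[nH]c3C2(C)C)CC1`: 2680 nM
- compound 3 `CCCNC(=O)Nc1n[nH]c2c1CN(C(=O)C1CCN(C)CC1)C2(C)C`: 650 nM

Compound 3 holds the second highest of the three numbers, with compound 2 on one side, a 4.1-fold lower number from compound 2 to compound 3 (0.62 log units; beyond the scatter), and compound 1 on the other, a 4.6-fold higher number from compound 1 to compound 3 (0.67 log units; beyond the scatter).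

The next compound is compound 4 `CN1CCC(C(=O)N2Cc3c(NC(=O)c4ccccc4)n[nH]c3C2(C)C)CC1`, with phenyl in place of propylamino on a carbonyl carbon. Read one bond further out, this is (propylcarbamoyl)amino to benzamido.

Two measured steps change the same carbonyl substituent. Replacing cyclobutyl with propylamino gave a 4.6-fold higher number from compound 1 to compound 3 (0.67 log units; beyond the scatter), and replacing it with benzylamino gave a 19-fold higher number from compound 1 to compound 2 (1.28 log units; beyond the scatter). In both, the amino-linked group goes with the higher number, and neither compound goes against this. Compound 4 loses that amino link, so it should sit nearer compound 1 at 140 nM. For the measured compounds named here, one caution is that the only measured compound with a phenyl ring, compound 2, has the highest number at 2680 nM, although its ring is carried on a chain. Going by the values given here, no measured compound has phenyl directly on this carbonyl carbon, so the range stays wide.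

A modest drop is therefore expected in this assay, estimated as a 3.8-fold lower number from compound 3 to compound 4 (0.58 log units; beyond the scatter). The estimated value for compound 4 is 170 nM, with an expected range of 50 nM to 600 nM.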

Compound 4, half-maximal inhibitory concentration in the A2780 assay: 160 nM
For compound 4 the middle estimate is 1.1-fold (0.03 log units) above the measured one, and the stated range covers the measured number.
By their numbers in the A2780 assay, from the lowest: compounds 1 and 4 (each within the scatter of the next); then compound 3; then compound 2.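

In the A2780 assay, phenyl on the carbonyl carbon brings the number down from both amino-linked compounds, with a 4.1-fold lower number from compound 3 to compound 4 (0.61 log units; beyond the scatter) and a 17-fold lower number from compound 2 to compound 4 (1.22 log units; beyond the scatter). Against cyclobutyl the change gives a 1.1-fold higher number from compound 1 to compound 4 (0.06 log units; within the scatter), so phenyl and cyclobutyl are not told apart at this position. For the compounds shown here, a phenyl ring as such therefore does not go with the high number of compound 2, as compound 4 also carries one, and across the four compounds the two amino-linked groups, in compound 2 and compound 3, hold the higher numbers, with no compound going against this.

In a physicochemical assay for solubility, at pH 7 (on this read-out lower numbers stand for lower solubility and higher numbers for higher solubility), compound 3 gives > 225000 nM, which is a limit of the assay and not a number. In the physicochemical assay compound 4 gives > 225000 nM, which is also a limit of the assay and not a number. From the compounds shown here alone, in the physicochemical assay the step from compound 3 to compound 4 cannot be read, as both values are limits of the assay and not numbers: the limit of > 225000 nM in the physicochemical assay, at which 2 of the 2 values shown sit. Still open is how a phenyl ring carrying an amine or a carboxylic acid, or a longer carbon chain without the amino link, would behave on this carbonyl carbon in the A2780 assay, and whether either would separate from phenyl and cyclobutyl.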